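Aryl exchange on the sulfonyl sulfur of compound 1

The source may hold more compounds than are shown below. What is called first, only, known or untested is meant among the compounds shown, and "the series" means these compounds.

Compound 1 `CC1CCN(C2CCN(S(=O)(=O)c3cccnc3Cl)CC2)CC1` has been run in a functional assay on DLD-1 cells (Homo sapiens) for antiproliferative activity, read by CellTiter-Glo, with a stated time of 72 h; on this read-out higher numbers stand for weaker inhibition and lower numbers for stronger inhibition. Compound 1 returns only a limit, > 5000 nM. On the numbers shown compound 1 therefore sits at the limit of > 5000 nM in this assay, at which 1 of the 2 values shown sits, the weak end of the pair. Compound 2 `Cc1cc(C)c(S(=O)(=O)N2CCN(C3CCN(C)CC3)CC2)c(C)c1` gives 426 nM in this assay. No two measured compounds differ in one place, so no step size is shown. Compound 3 `CC1CCN(C2CCN(S(=O)(=O)c3cccc(N)c3)CC2)CC1` carries 3-aminophenyl in place of 2-chloropyridin-3-yl on a sulfonyl sulfur. The step of an at least 1.6-fold lower number from compound 1 to compound 3 (0.22 log units; that floor lies within the scatter) is expected to be modest, toward stronger inhibition, with a real chance of none beyond the scatter. Compound 3 is estimated at 3000 nM, in the range 800 nM to 10000 nM.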

Compound 3, half-maximal inhibitory concentration: 3400 nM
Estimate against measurement, compound 3: 1.1-fold (0.05 log units) below; low and high end bracket the measured number.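

On the sulfonyl sulfur, 3-aminophenyl in place of 2-chloropyridin-3-yl gives an at least 1.4-fold lower number from compound 1 to compound 3 (0.16 log units; that floor lies within the scatter) in this assay. Within the data shown here, this is the first measured number at this position on the core of compound 1, and compound 3 gives 3400 nM. Compound 1 stands at a limit, so only a floor for the step can be read: the limit of > 5000 nM in this assay, at which 1 of the 3 values shown sits.

From the compounds shown here alone, it remains open whether any real difference rests on the amine, the chlorine or the ring nitrogen. Going by these compounds, how a 3-methoxyphenyl or 3-carboxyphenyl group on the sulfonyl sulfur would read is also open.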